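The source may report more compounds than this note shows. Statements on the series, on what has been measured and on what is new or still open speak of the compounds shown alone.

Measured compounds in an assay on RAW264.7 cells for antagonist activity at Toll-like receptor 2 (Mus musculus), read by Griess assay, with a stated time of 24 h; on this read-out higher numbers stand for weaker inhibition and lower numbers for stronger inhibition:

- compound 1, `C=CCCCSC[C@H](N)C(=O)OC`: in this assay compound 1 gives 31300 nM
- compound 2, `C#CCSC[C@H](NC(=O)c1cc(OC)c(OC)c(OC)c1)C(=O)OC`: in this assay compound 2 gives 53200 nM
- compound 3, `C=CCCSC[C@H](NC(=O)c1cc(O)c(O)c(O)c1)C(=O)OC`: in this assay compound 3 gives 57800 nM

Compound 3 carries the highest number of the three, yet its distance to compound 2 is negligible and its distance to compound 1 also lies within the usual scatter of this assay, so the three compounds cannot be placed in any order of strength on these numbers. Among the compounds with values here, none of the pairs among them differs in one place only, so no single structural step has been read from measurement here.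

Compound 4, `COC(=O)[C@H](CSCc1ccccc1)NC(=O)c1cc(O)c(O)c(O)c1`, is the next compound to be tested in this assay. It differs from compound 3 in one place: phenyl in place of allyl on a saturated chain carbon bound to a sulfur. The rest of the molecule, including the amide and the ester, is kept as in compound 3.

Within the data shown here, with no measured step of this kind among the three compounds, there is no basis for a direction, and the step from compound 3 to compound 4 is expected to stay within the scatter, a 1.3-fold lower number from compound 3 to compound 4 (0.11 log units; within the scatter). For compound 4 an inhibitory concentration of 45000 nM is therefore estimated, with a range from 15000 nM to 130000 nM.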

Compound 4, half-maximal inhibitory concentration: 60700 nM
Estimate against measurement, compound 4: 1.3-fold (0.13 log units) below; the range from low to high includes it.
By their numbers in this assay, from the lowest: compounds 1, 2, 3 and 4 (each within the scatter of the next).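

Within the data shown here, the step from compound 3 gives the first reading at this position: in this assay, phenyl in place of allyl on a saturated chain carbon bound to a sulfur gives a 1.1-fold higher number from compound 3 to compound 4 (0.02 log units; within the scatter). Read one bond further out, the but-3-en-1-yl group and the benzyl group on the sulfur cannot be told apart on this read-out, although one is an open chain with a double bond and the other carries a six-membered aromatic ring of carbon only. This holds for this one pair, in which the amide and the ester stay the same, and no measurement at hand accounts for the result.

The compounds shown leave open whether any group at this place can produce a step beyond the usual scatter, for example a longer chain, an amine at the end of the chain, or a phenyl ring bearing a methoxy group. They also leave open how the number would respond elsewhere in the molecule, for example to a carboxylic acid in place of the methyl ester in compound 4.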